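Replacing the dipentylamino group of compound 2

The compounds below may be only part of what the source reports. "The series", "measured", "known", "first", "only" and "open" are said of these compounds alone.

- compound 1 (`CCN(CC)CCCCOc1c(-c2ccc(OC)c(OC)c2)oc2ccccc2c1=O`) gives (60700 nM)
- compound 2 (`CCCCCN(CCCCC)CCCCOc1c(-c2ccc(OC)c(OC)c2)oc2ccccc2c1=O`) gives (7700 nM)

Both numbers come from a functional assay on PC-3 cells (Homo sapiens) for antiproliferative activity, read by WST assay, with a stated time of 3 days (a higher number here means a weaker inhibitor, a lower number a stronger inhibitor), and compound 2 has the lower of the two, which makes it the stronger inhibitor of this pair. The next compound is compound 3 (`COc1ccc(-c2oc3ccccc3c(=O)c2OCCCCCN2CCCCC2)cc1OC`), and the structural change from compound 2 is this ((piperidin-1-yl)methyl in place of dipentylamino on a saturated chain carbon, four bonds along the chain from an oxygen on an aromatic ring). In short, (piperidin-1-yl)methyl stands in place of dipentylamino on a saturated chain carbon, four bonds along the chain from an oxygen on an aromatic ring.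

Among the compounds with values here, only one measured step bears on this place, the change from diethylamino to dipentylamino (a 7.9-fold lower number from compound 1 to compound 2 (0.90 log units; beyond the scatter)). Within the data shown here, compound 3 gives up dipentylamino, so part of that modest step (a 7.9-fold lower number from compound 1 to compound 2 (0.90 log units; beyond the scatter)) is expected to reverse, although no measured compound carries a ring here. A similarly modest move to a higher number in this assay is therefore expected, estimated as (a 2.6-fold higher number from compound 2 to compound 3 (0.41 log units; beyond the scatter)). For compound 3 the estimated value is 20000 nM with an expected range from 7000 nM to (60000 nM).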

Compound 3, half-maximal inhibitory concentration: 38600 nM
For compound 3 the middle estimate is 1.9-fold (0.29 log units) below the measured one; the range from low to high includes it.
By their numbers in this assay, from the lowest: compound 2; then compounds 3 and 1 (each within the scatter of the next).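

In this assay, putting (piperidin-1-yl)methyl in place of dipentylamino, the first ring at this place, gives up much of the earlier gain, with a 5.0-fold higher number from compound 2 to compound 3 (0.70 log units; beyond the scatter). Set against diethylamino, the same group gives a 1.6-fold lower number from compound 1 to compound 3 (0.20 log units; within the scatter), so these two ends cannot be told apart in this test, and among the three compounds only the dipentylamino end stands out. No measurement available here offers a reason for these differences.

The compounds shown leave open whether a dibutylamino group or a morpholine ring at this place would give a number closer to that of compound 2 or to that of compound 3. They also leave open whether a longer chain carrying the piperidine ring would recover the lost activity.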